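This account rests on a few compounds, and the source may have more. Where it says the series, first, only, none or still open, it means among the compounds named here.

Measured compounds:
Compound 1 `CCCCCCCC/C=C\CCCCCCCCNC(=O)Nc1c(C)cccc1C` — 160 nM
Compound 2 `CCCCCCCCCCCCCCCCCCNC(=O)Nc1c(C)cccc1C` — 610 nM; 610 nM (2 entries)

Compound 1 and compound 2 share the same core and differ only in the long chain. In an assay on microsomes from intestinal mucosa for inhibition of acyl-CoA:cholesterol acyltransferase (Oryctolagus cuniculus) (on this read-out lower numbers stand for stronger inhibition and higher numbers for weaker inhibition), compound 1 gives 160 nM, and compound 2 gives 610 nM; 610 nM (2 entries) in each of its two entries; the number of compound 1 is the lower of the two, so among the compounds with a number compound 1 is the stronger inhibitor in this assay.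

Compound 3 `CCCCCCCC/C=C\CCCCCCCCNC(=O)c1c(C)cccc1C` has not yet been measured. It keeps the chain of compound 1, and the change is 2,6-dimethylphenyl in place of (2,6-dimethylphenyl)amino on a carbonyl carbon. Among the compounds with values here, no measured pair shows the effect of such a change here, so the expectation rests on compound 1 alone. The step from compound 1 to compound 3 is expected to be a modest loss, a 2.5-fold higher number from compound 1 to compound 3 (0.40 log units; beyond the scatter), which may or may not exceed the usual scatter. Compound 3 is therefore estimated at 400 nM, with a plausible range from 100 nM to 1600 nM.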

Compound 3, half-maximal inhibitory concentration: 9800 nM
Compound 3: the middle estimate sits 25-fold (1.39 log units) below what was measured; the measured number lies above the stated range.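

Replacing (2,6-dimethylphenyl)amino with 2,6-dimethylphenyl on the carbonyl carbon removes only one nitrogen and its hydrogen-bond donor, leaving the aromatic ring, its two methyl groups and the long chain in place. In this assay, this small edit gives a 61-fold higher number from compound 1 to compound 3 (1.79 log units; beyond the scatter), so activity at this position is far more sensitive to the change than the first two compounds, which differ only in the chain, could reveal. Nothing shown here establishes why the loss is so large.

As far as these compounds go, it remains open whether an oxygen or a methylene carbon in place of that nitrogen would retain the activity of compound 1. It is also unknown whether the same change would cost as much on the chain of compound 2.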